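Shortening the basic side chain in a cyclic peptide series

The compounds below may be only part of what the source reports. "The series", "measured", "known", "first", "only" and "open" are said of these compounds alone.

Compound 1 `CC(C)C[C@@H]1NC(=O)[C@H](CCCNC(=N)N)NC(=O)[C@H](CCCCN)NC(=O)[C@H](CC(=O)O)NC(=O)[C@H](CCCCN)NC(=O)CCNC1=O`: 1650 nM
Compound 2 `CC(C)C[C@@H]1NC(=O)[C@H](CCCNC(=N)N)NC(=O)[C@H](CN)NC(=O)[C@H](CC(=O)O)NC(=O)[C@H](CCCCN)NC(=O)CCNC1=O`: > 5000 nM
Compound 3 `CC(C)C[C@@H]1NC(=O)[C@H](CCCNC(=N)N)NC(=O)[C@H](CCN)NC(=O)[C@H](CC(=O)O)NC(=O)[C@H](CCCCN)NC(=O)CCNC1=O`: to be measured

In an assay on COS-7 cells for inhibition of disintegrin and metalloproteinase domain-containing protein 8 (Homo sapiens), read by ELISA, with a stated time of 6 h (a lower number here means a stronger inhibitor, a higher number a weaker inhibitor), compound 1 gives 1650 nM. Compound 2 reaches only the limit of this assay, > 5000 nM, so its true value is not known (the limit of > 5000 nM in this assay, at which 1 of the 2 values shown sits). The step of an at least 3.0-fold higher number from compound 1 to compound 2 (0.48 log units; beyond the scatter) shows that cutting the chain back sharply costs potency. Compound 3 carries the change (aminomethyl in place of amino on a saturated chain carbon bound to a saturated ring carbon), restoring one carbon of that chain. Its value is expected to lie between those of compound 1 and compound 2; the step of an at least 1.2-fold lower number from compound 2 to compound 3 (0.09 log units; that floor lies within the scatter) is thus expected to be a gain, though it may remain at the limit. Compound 3 is estimated at 4000 nM, between 1800 nM and 12000 nM.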

Compound 3, half-maximal inhibitory concentration: > 5000 nM
Compound 3: a limit, no number (the forecaster's own chance of this, stated with the estimate: 40%); middle value at least 1.2-fold (0.09 log units) from the limit.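

With the 2-aminoethyl chain, compound 3 still gives no number in this assay, so adding one carbon to the aminomethyl chain of compound 2 does not yield a measurable value. The loss therefore extends beyond the shortest chain, with an at least 3.0-fold higher number from compound 1 to compound 3 (0.48 log units; beyond the scatter). The step between compound 2 and compound 3 cannot be read, and no order can be given for them, as both values are limits: the limit of > 5000 nM in this assay, at which 2 of the 3 values shown sit.

From the compounds shown here alone, it remains open whether a 3-aminopropyl chain at this position would recover a measurable value. Also open, going by these compounds, is how a guanidine on a chain of this length would compare.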